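The compounds below may be only part of what the source reports. "The series", "measured", "known", "first", "only" and "open" are said of these compounds alone.

Three compounds have been measured in an assay on microsomes from brain for inhibition of heme oxygenase 2 (Rattus norvegicus), using NADPH, with stated times of 10 min and 15 min; on this read-out lower numbers stand for stronger inhibition and higher numbers for weaker inhibition:

Compound 1 `c1ccc(CCCCCCn2ccnc2)cc1`: 20000 nM
Compound 2 `Brc1ccc(Cn2c(CC3CCCC3)nc3ccccc32)cc1`: 8400 nM
Compound 3 `c1ccc(Cn2c(CC3CC4CCC3C4)nc3ccccc32)cc1`: 6300 nM

Compound 3 gives the lowest of the three numbers, though compound 2 lies within the scatter of it, so the two cannot be ranked; compound 1 sits beyond the scatter with a higher number. Compound 4 `Brc1ccc(Cn2c(CC3CC4CCC3C4)nc3ccccc32)cc1` has not yet been measured. It differs from compound 3 by bromo in place of hydrogen on an aromatic carbon; cut one bond further out, benzyl becomes 4-bromobenzyl. Within the data shown here, no measured pair shows this change on its own: compound 2 carries a bromo but also a different group on the shared core, so its value and that of compound 3 show only that they lie within the scatter. The step from compound 3 to compound 4 is therefore expected to be small, a 1.4-fold lower number from compound 3 to compound 4 (0.15 log units; within the scatter), probably within the scatter. Compound 4 is estimated at 4500 nM, within a range from 2000 nM to 10000 nM.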

Compound 4, half-maximal inhibitory concentration: 5100 nM
Estimate against measurement, compound 4: 1.1-fold (0.05 log units) below; measured number inside the range.
By their numbers in this assay, from the lowest: compounds 4, 3 and 2 (each within the scatter of the next); then compound 1.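

In this assay, among these compounds, bromo in place of hydrogen on an aromatic carbon is seen on its own for the first time and gives a 1.2-fold lower number from compound 3 to compound 4 (0.09 log units; within the scatter) so at this place, para to a large group, the change has no effect that can be told from the scatter. Exchanging the group on the saturated chain carbon gives a 1.6-fold lower number from compound 2 to compound 4 (0.22 log units; within the scatter) and cannot be told from the scatter either. Nothing available explains these results. From the compounds shown here alone, whether an amine or a carboxylic acid in place of the bromo would shift the number beyond the scatter remains open.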